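The source may report more compounds than this note shows. Statements on the series, on what has been measured and on what is new or still open speak of the compounds shown alone.

Three compounds built on one shared core have been run in a functional assay on HEK293 cells for agonist activity at lutropin-choriogonadotropic hormone receptor (Homo sapiens), read by cAMP accumulation; a lower number here means a smaller maximal response, a higher number a larger maximal response. Compound 1 `CSc1nc(-c2cccc(F)c2)c2c(N)c(C(=O)NC(C)(C)C)sc2n1` gives 51.1% in this assay. Compound 3 `COc1cccc(-c2nc(SC)nc3sc(C(=O)NC(C)(C)C)c(N)c23)c1OC` gives 50.1% in this assay, a value within the usual scatter of compound 1. Compound 2 `COc1cccc(-c2nc(SC)nc3sc(C(=O)NNC(C)(C)C)c(N)c23)c1` gives 6% in this assay, the lowest of the three numbers: its nearest neighbour is compound 3, whose value lies higher by a margin beyond the scatter, and compound 1 lies further away still, also beyond the scatter.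

The core of compound 2 is kept in compound 4 `COc1cccc(-c2nc(SC)nc3sc(C(=O)OC(C)(C)C)c(N)c23)c1`, which has not yet been measured. Compound 4 differs from compound 2 in one place: tert-butoxy in place of ((tert-butyl)amino)amino on a carbonyl carbon Neither compound 1 nor compound 3 carries the ((tert-butyl)amino)amino group, and both reach roughly half of the reference response, whereas compound 2 sits near the floor. Among the compounds with values here, no measured pair shows this exact exchange, so the size of the move is uncertain. An upward step is expected for compound 4, estimated as a number 29 percentage points higher from compound 2 to compound 4 (beyond the scatter). Compound 4 is estimated to give 35% in this assay, within a range from 5% to 65%.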

Compound 4, largest response reached (reported as efficacy), in percent of the reference or control that the assay uses: 23.8%
The estimate for compound 4 lay 11.2 percentage points above the measured number; measured number inside the range.
By their numbers in this assay, from the lowest: compound 2; then compound 4; then compounds 3 and 1 (each within the scatter of the next).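

In this assay, within the data shown here, this exchange gives the first direct reading of a change on this carbonyl carbon, with the rest of the molecule held constant: tert-butoxy in place of ((tert-butyl)amino)amino gives a number 17.8 percentage points higher from compound 2 to compound 4 (beyond the scatter), a modest step. The very low response of compound 2 therefore does not come from the shared core and its other substituents alone, since the group on the carbonyl carbon alters the maximal response, though compound 4 still reaches only 23.8%. The exchange also removes the hydrogen-bond donors of the departing group, but nothing available connects that or any other feature of the two groups to the size of the step.

From the compounds shown here alone, a single pair gives one step at this position, so it remains open how a carboxylic acid, a simple tert-butylamine amide or a longer chain on the same carbonyl carbon would compare with tert-butoxy when everything else matches compound 4. Going by these compounds, it is equally open whether the exchange would give a step of similar size and the same direction if the substituents elsewhere on the shared core were different.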